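Moving the Halogen on the Aryl Group of Compound 3

The source may hold more compounds than are shown below. What is called first, only, known or untested is meant among the compounds shown, and "the series" means these compounds.

Going by the values given here, compound 3 `Nc1ncnn2c([C@@H]3O[C@H](CO)[C@@H](O)[C@H]3O)cc(-c3ccc(Cl)cc3)c12` is the one compound here with a number in a functional assay on K562 cells (Homo sapiens) for antiproliferative activity, with a stated time of 72 h (a higher number here means a weaker inhibitor, a lower number a stronger inhibitor), giving 47800 nM. Compound 1 `Nc1ncnn2c([C@@H]3O[C@H](CO)[C@@H](O)[C@H]3O)cc(C#Cc3cccs3)c12` gives in this assay > 100000 nM, which is a limit of the assay and not a number. Compound 2 `Nc1ncnn2c([C@@H]3O[C@H](CO)[C@@H](O)[C@H]3O)cc(-c3ccc(F)cc3)c12` likewise gives in this assay > 100000 nM, again a limit rather than a number. Both limits sit at the limit of > 100000 nM in this assay, at which 2 of the 3 values shown sit. Compound 4 `Nc1ncnn2c([C@@H]3O[C@H](CO)[C@@H](O)[C@H]3O)cc(-c3ccccc3F)c12` carries 2-fluorophenyl in place of 4-chlorophenyl on an aromatic carbon. Among the compounds with values here, the one measured step that bears on this change is an at least 2.0-fold lower number from compound 2 to compound 3 (0.32 log units; beyond the scatter), since compound 4 returns to fluoro, though at a different position on the ring. A rise in the number is therefore expected, possibly back to the limit. The estimate for compound 4 in this assay is 100000 nM, between 40000 nM and 300000 nM, an expected step of a 2.1-fold higher number from compound 3 to compound 4 (0.32 log units; beyond the scatter).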

Compound 4, half-maximal inhibitory concentration: > 100000 nM
Compound 4: no number, only a limit (the forecaster's own chance of this, stated with the estimate: 55%); the middle value lies on the limit itself.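

The step shows that 2-fluorophenyl does not keep what little activity 4-chlorophenyl gives at this position: an at least 2.0-fold higher number from compound 3 to compound 4 (0.32 log units; beyond the scatter). The steps linking compound 4 to compound 1 and compound 2 cannot be read, as both ends are limits. The result for compound 4 in this assay is itself a limit and not a number: the limit of > 100000 nM in this assay, at which 3 of the 4 values shown sit.

This step changes the halogen and its place on the ring together, leaving the share of each unresolved. As far as these compounds go, whether 2-chlorophenyl or 4-bromophenyl would match or improve on compound 3 remains open.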